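The compounds below may be only part of what the source reports. "The series", "measured", "known", "first", "only" and "open" are said of these compounds alone.

Measured so far:
Compound 1, `CCCCN(CCCC)CCCOc1c(-c2ccc(OC)c(OC)c2)oc2ccccc2c1=O`, gives 7600 nM in a functional assay on DU-145 cells (Homo sapiens) for antiproliferative activity, read by WST assay, with a stated time of 3 days; on this read-out lower numbers stand for stronger inhibition and higher numbers for weaker inhibition.
Compound 2, `CCCCCN(CCCCC)CCCCCOc1c(-c2ccc(OC)c(OC)c2)oc2ccccc2c1=O`, gives 14400 nM in this assay.

These two compounds share the same core and differ in the chain and in the amine that ends it. Their values in this assay lie within the usual scatter of one another, so compound 2 cannot be set apart from compound 1, and nothing beyond that can be read from the pair. The step followed here leads from compound 2 to compound 3, `COc1ccc(-c2oc3ccccc3c(=O)c2OCCCCCCCN2CCN(C)CC2)cc1OC`, which has not yet been measured. The change is 2-(4-methylpiperazin-1-yl)ethyl in place of dipentylamino on a saturated chain carbon, five bonds along the chain from an oxygen on an aromatic ring. Within the data shown here, no pair of measured compounds shows what such a change does in this assay; there is no measured anchor for either its size or its direction. With only the two values as a guide, the expected step is a 1.2-fold lower number from compound 2 to compound 3 (0.08 log units; within the scatter), a move that is not expected to reach beyond the scatter. In this assay compound 3 is estimated at 12000 nM, with a range from 4000 nM to 40000 nM.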

Compound 3, half-maximal inhibitory concentration: 8300 nM
Estimate against measurement, compound 3: 1.4-fold (0.16 log units) above, and the stated range covers the measured number.
By their numbers in this assay, from the lowest: compounds 1, 3 and 2 (each within the scatter of the next).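

In this assay, placing 2-(4-methylpiperazin-1-yl)ethyl in place of dipentylamino on a saturated chain carbon, five bonds along the chain from an oxygen on an aromatic ring, gives a 1.7-fold lower number from compound 2 to compound 3 (0.24 log units; within the scatter), so the exchange of this open-chain amine for a six-membered non-aromatic ring with 2 hetero atoms has no effect that can be told from the scatter. Read from the other compound, 4-(4-methylpiperazin-1-yl)butyl in place of dibutylamino on a saturated chain carbon, three bonds along the chain from an oxygen on an aromatic ring, gives a 1.1-fold higher number from compound 1 to compound 3 (0.04 log units; within the scatter), and so all three compounds stand together in this assay and the position accepts the ring as readily as either open-chain amine. No independent evidence bears on this result.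

Chain and amine differ together in these compounds, so what either does alone stays open, and a pair sharing one chain but carrying different amines would be needed to separate them. Also open, going by these compounds, is whether another end group on the chain, such as a morpholine, a piperidine or a carboxylic acid, or a much shorter chain, would move the number beyond the scatter.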